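The source may hold more compounds than are shown below. What is called first, only, known or untested is meant among the compounds shown, and "the series" means these compounds.

For the measured compounds named here, compound 2 `CC(C)c1n[nH]c2c(NCc3ccc(-c4ccccn4)cc3)nc(SC[C@H](O)CN)nc12` gives 63 nM in a functional assay on HT cells (Homo sapiens) for antiproliferative activity, read by fluorescence, with a stated time of 72 h (on this read-out higher numbers stand for weaker inhibition of growth and lower numbers for stronger inhibition of growth), the smaller of the two numbers measured so far, though its distance from compound 1 is within the scatter. Compound 1 `CC(C)c1n[nH]c2c(NCc3ccc(-c4ccccn4)cc3)nc(SCC3CNC(=O)O3)nc12` gives 80 nM in this assay. Compound 3 `CC(C)c1n[nH]c2c(NCc3ccc(-c4ccccn4)cc3)nc(SCC(N)CN)nc12` is the unmeasured neighbour of compound 2: 1,2-diaminoethyl in place of 2-amino-1-hydroxyethyl on a saturated chain carbon bound to a sulfur. Going by the values given here, the one measured step at this same place, a 1.3-fold lower number from compound 1 to compound 2 (0.10 log units; within the scatter), stayed within the scatter. For compound 3 no step beyond the scatter is therefore expected in this assay, a 1.1-fold higher number from compound 2 to compound 3 (0.05 log units; within the scatter). Compound 3 is accordingly estimated at 70 nM, with a range from 30 nM to 170 nM.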

Compound 3, concentration for 50% growth inhibition: 480 nM
Beside the measured number, compound 3's estimate is 6.9-fold (0.84 log units) below it, outside the stated range (above it).
By their numbers in this assay, from the lowest: compounds 2 and 1 (each within the scatter of the next); then compound 3.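

In this assay, this place on a saturated chain carbon bound to a sulfur proves sensitive to the change: 1,2-diaminoethyl in place of 2-amino-1-hydroxyethyl gives a 7.6-fold higher number from compound 2 to compound 3 (0.88 log units; beyond the scatter), and in place of 2-oxo-1,3-oxazolidin-5-yl it gives a 6.0-fold higher number from compound 1 to compound 3 (0.78 log units; beyond the scatter). Both steps lie beyond the scatter, although 2-amino-1-hydroxyethyl and 1,2-diaminoethyl have the same counts of heavy atoms, hydrogen-bond donors and acceptors. Nothing measured here explains the loss. Still open, on these data alone, is how a single defined stereocentre in 1,2-diaminoethyl, a methoxy group in place of its first amine, or a longer chain would read.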